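From Indanyl to 2-Fluorobenzyl on the Amine of Compound 1

The source may report more compounds than this note shows. Statements on the series, on what has been measured and on what is new or still open speak of the compounds shown alone.

compound 1 `NS(=O)(=O)OC[C@@H]1C[C@@H](n2nnc3c(N[C@H]4CCc5ccccc54)ncnc32)C[C@@H]1O`: 0.21 nM
compound 2 `NS(=O)(=O)OC[C@@H]1C[C@@H](Nc2ncnc(N[C@H]3CCc4ccccc43)c2F)C[C@@H]1O`: 219 nM

In an assay on a protein complex for inhibition of NEDD8 activating enzyme (Homo sapiens), read by HTRF, with a stated time of 2 h, in the presence of a further agent that is not named here (on this read-out lower numbers stand for stronger inhibition and higher numbers for weaker inhibition), compound 1 gives 0.21 nM, the lowest of the two numbers shown. Compound 2 gives 219 nM, a gap well beyond the usual scatter.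

Compound 3 `NS(=O)(=O)OC[C@@H]1C[C@@H](n2nnc3c(NCc4ccccc4F)ncnc32)C[C@@H]1O` differs from compound 1 in one place: 2-fluorobenzyl in place of 2,3-dihydro-1H-inden-1-yl on a nitrogen on an aromatic ring. For the measured compounds named here, no measured pair shows this exact change, so the expectation rests only on the change itself. A rise in the number is expected, of the size a 24-fold higher number from compound 1 to compound 3 (1.38 log units; beyond the scatter). Compound 3 is accordingly estimated at 5 nM, with a range from 1 nM to 30 nM.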

Compound 3, half-maximal inhibitory concentration: 6.11 nM
Estimate against measurement, compound 3: 1.2-fold (0.09 log units) below, and the stated range covers the measured number.
By their numbers in this assay, from the lowest: compound 1; then compound 3; then compound 2.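

In this assay, putting 2-fluorobenzyl on this nitrogen gives a 29-fold higher number from compound 1 to compound 3 (1.46 log units; beyond the scatter), so activity here depends strongly on the group carried. Even so, compound 3 keeps a low number of 6.11 nM with one six-membered aromatic ring and no defined stereocentre in this group, so neither the five-membered ring nor the stereocentre is needed for substantial inhibition. Nothing shown accounts for the size of this step.

On these data alone, whether the fluorine matters remains open, and a plain benzyl group would test it. A longer chain, such as 2-phenylethyl, would show how the distance from this nitrogen to the ring affects inhibition.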